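The source may hold more compounds than are shown below. What is called first, only, known or untested is meant among the compounds shown, and "the series" means these compounds.

Compound 3 `O=C1N[C@H]2[C@H](CS[C@H]2CCCCCc2cn(Cc3ccccc3F)nn2)N1` belongs to a small set of analogues that share one core and differ only in the group on the saturated chain carbon bound to an aromatic nitrogen. In an assay on isolated protein for inhibition of biotin--protein ligase (Homo sapiens), read by scintillation counting, with a stated time of 10 min (a lower number here means a stronger inhibitor, a higher number a weaker inhibitor), compound 3 gives only a limit, > 16000 nM. Compound 1 `O=C1N[C@H]2[C@H](CS[C@H]2CCCCCc2cn(Cc3ccccc3O)nn2)N1` likewise stops at a limit in this assay, giving > 16000 nM. Compound 2 `COc1ccccc1Cn1cc(CCCCC[C@@H]2SC[C@@H]3NC(=O)N[C@@H]32)nn1` also reaches only a limit in this assay, at > 16000 nM. The steps among these three, a step that the two limits leave unreadable from compound 1 to compound 2, a step that the two limits leave unreadable from compound 1 to compound 3 and a step that the two limits leave unreadable from compound 2 to compound 3, cannot be read in size or direction because of the limit of > 16000 nM in this assay, at which 3 of the 3 values shown sit. Compound 4 `O=C1N[C@H]2[C@H](CS[C@H]2CCCCCc2cn(Cc3ccc(F)cc3)nn2)N1` is the next analogue, and its change from compound 3 is 4-fluorophenyl in place of 2-fluorophenyl on a saturated chain carbon bound to an aromatic nitrogen. Going by the values given here, none of the measured steps bears a readable size on this change, so the only guide is that every value so far sits at the limit. The expected step that the limit leaves unreadable from compound 3 to compound 4 is therefore none beyond the scatter, with compound 4 expected to stay at the limit as well. Compound 4 is estimated at 30000 nM, within a range from 10000 nM to 100000 nM.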

Compound 4, inhibition constant: > 16000 nM
Compound 4 gave a limit, no number (the forecaster's own chance of this, stated with the estimate: 85%); the middle value does not contradict the limit.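

The steps from compound 1, compound 2 and compound 3 to compound 4 cannot be read in size or direction, because compound 4 also stops at a limit in this assay: the limit of > 16000 nM in this assay, at which 4 of the 4 values shown sit.

The compounds shown leave open how strongly any of the four inhibits the protein, and whether 2-fluorophenyl and 4-fluorophenyl differ at all.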